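Swapping the Ring on the Sulfonamide Nitrogen

The source may report more compounds than this note shows. Statements on the series, on what has been measured and on what is new or still open speak of the compounds shown alone.

Three compounds share one core and differ only in the aromatic ring attached to the sulfonamide nitrogen. In a functional assay on OVCAR-8 cells (Homo sapiens) for inhibition, read by sulforhodamine B assay, with a stated time of 48 h (on this read-out lower numbers stand for stronger inhibition of growth and higher numbers for weaker inhibition of growth), compound 1 `C=C1CC[C@@H]2[C@](C)(COC(C)=O)[C@H](OC(C)=O)CC[C@@]2(C)[C@H]1CC(Nc1ccc(S(=O)(=O)Nc2nccc(C)n2)cc1)C1=CCOC1=O` gives 8560 nM, compound 2 `C=C1CC[C@@H]2[C@](C)(COC(C)=O)[C@H](OC(C)=O)CC[C@@]2(C)[C@H]1CC(Nc1ccc(S(=O)(=O)Nc2nccs2)cc1)C1=CCOC1=O` gives 10800 nM, and compound 3 `C=C1CC[C@@H]2[C@](C)(COC(C)=O)[C@H](OC(C)=O)CC[C@@]2(C)[C@H]1CC(Nc1ccc(S(=O)(=O)Nc2ncccn2)cc1)C1=CCOC1=O` gives 3550 nM. Compound 3 therefore shows the lowest number of the three, and both of its gaps to the others lie beyond the scatter: a 2.4-fold lower number from compound 1 to compound 3 (0.38 log units; beyond the scatter) and a 3.0-fold lower number from compound 2 to compound 3 (0.48 log units; beyond the scatter). By contrast, a 1.3-fold higher number from compound 1 to compound 2 (0.10 log units; within the scatter), so compounds 1 and 2 cannot be told apart on this read-out.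

Compound 4 `C=C1CC[C@@H]2[C@](C)(COC(C)=O)[C@H](OC(C)=O)CC[C@@]2(C)[C@H]1CC(Nc1ccc(S(=O)(=O)Nc2cc(C)on2)cc1)C1=CCOC1=O` is the next step from compound 3: 5-methyl-1,2-oxazol-3-yl in place of pyrimidin-2-yl on a sulfonamide nitrogen. Two measured steps speak to this change. Moving from a five-membered ring to the bare six-membered ring lowered the number, as seen in a 3.0-fold lower number from compound 2 to compound 3 (0.48 log units; beyond the scatter), and removing a methyl from the six-membered ring also lowered it, as seen in a 2.4-fold lower number from compound 1 to compound 3 (0.38 log units; beyond the scatter). Compound 4 reverses both directions at once, returning to a five-membered ring and carrying a methyl. The expectation for compound 4 is therefore a modest rise in the number, about a 2.3-fold higher number from compound 3 to compound 4 (0.35 log units; beyond the scatter). Compound 4 is estimated at 8000 nM, with a likely range from 3500 nM to 18000 nM.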

Compound 4, concentration for total growth inhibition: 4300 nM
Compound 4: the middle estimate sits 1.9-fold (0.27 log units) above what was measured, and the stated range covers the measured number.
By their numbers in this assay, from the lowest: compounds 3, 4, 1 and 2 (each within the scatter of the next, the first and the last beyond it).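

Compound 4 shows that a five-membered ring with a methyl can stand on the sulfonamide nitrogen without a readable loss against the bare six-membered ring: in this assay there is a 1.2-fold higher number from compound 3 to compound 4 (0.08 log units; within the scatter) and the two cannot be told apart. The five-membered rings themselves are not interchangeable, since there is a 2.5-fold lower number from compound 2 to compound 4 (0.40 log units; beyond the scatter) when 5-methyl-1,2-oxazol-3-yl takes the place of 1,3-thiazol-2-yl, so ring size alone does not set the number at this position. Compound 4 also sits close to the methylated six-membered ring, with a 2.0-fold lower number from compound 1 to compound 4 (0.30 log units; within the scatter) on the same read-out, which leaves it unseparated from both compound 1 and compound 3 even though those two stand apart.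

Still open, on these data alone, is whether this nitrogen needs a ring with two hetero atoms at all, or whether a plain phenyl ring, an acetyl group or a pyrimidin-2-yl carrying an amine would give a similar number. The data shown offer no measurement that explains why these rings differ from one another.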